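Compound 4 in the series: replacing the 4-chlorophenyl group

The source may hold more compounds than are shown below. What is called first, only, known or untested is meant among the compounds shown, and "the series" means these compounds.

Measured in an ADME assay on THP-1 cells (Homo sapiens) for cytotoxicity, read by MTT assay; a higher number here means that more compound is tolerated, a lower number that less compound is tolerated:
- Compound 1 `Cc1nc(-c2cccnc2)sc1-c1nnc(Cc2ccccc2)o1`: > 100 ug/mL, a limit
- Compound 2 `Cc1nc(-c2cccnc2)sc1-c1nnc(-c2ccc([N+](=O)[O-])cc2)o1`: > 100 ug/mL, a limit
- Compound 3 `Cc1nc(-c2cccnc2)sc1-c1nnc(-c2ccc(Cl)cc2)o1`: > 100 ug/mL, a limit

Compound 3 sits with compound 1 and compound 2 at the limit of > 100 ug/mL in this assay, at which 3 of the 3 values shown sit. No number is therefore available for compound 3, only a limit.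

The next compound, compound 4 `Cc1nc(-c2cccnc2)sc1-c1nnc(-c2ccncc2)o1`, has pyridin-4-yl in place of 4-chlorophenyl on an aromatic carbon. Going by the values given here, two measured steps bear on this change, as both alter the group at the same place on the shared core. Among the compounds with values here, the first is a step that the two limits leave unreadable from compound 1 to compound 3, and the second is a step that the two limits leave unreadable from compound 2 to compound 3. Neither has a readable size, so neither fixes a size for the new step or a direction.

With compound 3 at > 100 ug/mL, a limit, no step beyond the scatter is expected in this assay, and no direction is expected either. The expected step is a step that the limit leaves unreadable from compound 3 to compound 4. A report of a limit is the most likely outcome. The estimate for compound 4 is 120 ug/mL, with an expected range of 70 ug/mL to 300 ug/mL.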

Compound 4, half-maximal cytotoxic concentration: > 100 ug/mL
Compound 4: only a limit was reported; the forecaster's own chance of this, stated with the estimate: 85%; the middle value does not contradict the limit.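

In this assay compound 4 gives > 100 ug/mL, a limit and not a number. No step can be read between compound 4 and compound 3 or compound 1, as all share one limit: the limit of > 100 ug/mL in this assay, at which 4 of the 4 values shown sit. The compounds shown leave open how far any of them lies past that limit, and whether any group at this place on the shared core would bring a value within range.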